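Capping a Phenol Hydroxy with Methyl: Expected Solubility

This account rests on a few compounds, and the source may have more. Where it says the series, first, only, none or still open, it means among the compounds named here.

Compound 1 `COc1ccc(Cn2nnc(O)c2C(=O)Nc2cccc(C(F)(F)F)c2)cc1` gives 21200 nM in a physicochemical assay for solubility, read by HPLC, in phosphate buffer, with a stated time of 24 h, at pH 7.4; on this read-out lower numbers stand for lower solubility and higher numbers for higher solubility. Compound 2 `COc1ccc(Cn2nnc(O)c2C(=O)Nc2cccc(-c3ccccc3)c2)cc1` reaches only the limit of this assay, < 1000 nM. Compound 3 `COc1ccc(Cn2nnc(O)c2C(=O)Nc2cccc(-c3cccc(O)c3)c2)cc1` gives 40300 nM, one of two numbers shown, with compound 1 within the usual scatter of it (a 1.9-fold higher number from compound 1 to compound 3 (0.28 log units; within the scatter)). Compound 4 `COc1ccc(Cn2nnc(O)c2C(=O)Nc2cccc(-c3cccc(OC)c3)c2)cc1` differs from compound 3 by methyl in place of hydrogen on an oxygen on an aromatic ring. The step that bears most on this is an at least 40-fold higher number from compound 2 to compound 3 (1.60 log units; beyond the scatter), where the hydroxy entered; a methyl now covers that hydroxy, and the large step of an at least 21-fold lower number from compound 1 to compound 2 (1.32 log units; beyond the scatter) shows the plain phenyl far lower in this assay. A drop beyond the scatter is therefore expected, a 10-fold lower number from compound 3 to compound 4 (1.00 log units; beyond the scatter), though not the whole way back. Compound 4 is estimated at 4000 nM, between 1000 nM and 16000 nM.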

Compound 4, solubility: < 1000 nM
Compound 4 gave a limit, no number (the forecaster's own chance of this, stated with the estimate: 25%); middle value at least 4.0-fold (0.60 log units) away from the limit.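

Capping the hydroxy with methyl is enough on its own to lose the high reading in this assay, giving an at least 40-fold lower number from compound 3 to compound 4 (1.60 log units; beyond the scatter). So an oxygen on that ring does not suffice: 3-methoxyphenyl, unlike 3-hydroxyphenyl, also falls clearly short of trifluoromethyl, with an at least 21-fold lower number from compound 1 to compound 4 (1.32 log units; beyond the scatter). The step between the plain phenyl and the methoxy cannot be read, as compound 2 and compound 4 both stop at one limit: the limit of < 1000 nM in this assay, at which 2 of the 4 values shown sit.

The compounds shown leave open whether another group on that ring, such as an amine or a carboxylic acid, would read as high as the hydroxy of compound 3.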